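The source may hold more compounds than are shown below. What is called first, only, known or untested is meant among the compounds shown, and "the series" means these compounds.

Working notes on the series in an ADME assay on HaCaT cells (Homo sapiens) for inhibition, read by spectrophotometry and sulforhodamine B assay, with a stated time of 48 h; on this read-out lower numbers stand for stronger inhibition of growth and higher numbers for weaker inhibition of growth. Compound 1 (`Cc1ccc(N2C(=O)CS/C2=N/N=C/c2c[nH]c3ccc(Br)cc23)cc1`) gives 54000 nM, and compound 2 (`O=C1CS/C(=N/N=C/c2c[nH]c3ccccc23)N1c1cccc2ccccc12`) gives 63000 nM. Compound 3 (`S=C(N/N=C/c1c[nH]c2ccc(Br)cc12)Nc1cccc2ccccc12`) gives 6150 nM, the lowest of the three numbers, and its gaps to both of the others lie beyond the scatter.

Compound 4 (`S=C(N/N=C/c1c[nH]c2ccccc12)Nc1cccc2ccccc12`) has not yet been measured. Its structure departs from that of compound 3 by one change, hydrogen in place of bromo on an aromatic carbon of a six-membered aromatic ring of carbon only.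

Going by the values given here, no measured pair isolates this change, so the expectation rests on compound 3 at 6150 nM and carries wide uncertainty. A small move toward weaker inhibition of growth is expected, not clearly beyond the scatter. The expected size is a 1.8-fold higher number from compound 3 to compound 4 (0.25 log units; within the scatter). For compound 4 the estimated value is 11000 nM, with an expected range of 4500 nM to 30000 nM.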

Compound 4, concentration for 50% growth inhibition: 590 nM
Beside the measured number, compound 4's estimate is 19-fold (1.27 log units) above it, and the stated range ends above it.
By their numbers in this assay, from the lowest: compound 4; then compound 3; then compounds 1 and 2 (each within the scatter of the next).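

In this assay, hydrogen in place of bromo on this aromatic carbon, meta to a fused ring and para to a fused ring, gives a 10-fold lower number from compound 3 to compound 4 (1.02 log units; beyond the scatter), so the position is far from indifferent to what it carries, and on this core the unsubstituted carbon goes with the stronger inhibition of growth. The earlier compounds shown here could not show this, as no two of them differed at this position alone. Nothing at hand accounts for the size of this step.

On these data alone, whether the same change would carry a step of similar size on the cores of compound 1 and compound 2 remains open, as neither has a partner differing only here. Also open, as far as these compounds go, is how a chlorine, a methoxy group or an amine on this carbon would compare with hydrogen and bromo.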